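Working notes on the cytotoxicity series

The source may report more compounds than this note shows. Statements on the series, on what has been measured and on what is new or still open speak of the compounds shown alone.

Compound 1 `Cc1ccc(S(=O)(=O)N[C@@H](CC(=O)NC(C)(C)C)C(=O)NCCNC(=O)c2ccccc2)cc1` gives in an ADME assay on Karpas-1106P cells (Homo sapiens) for cytotoxicity (a higher number here means that more compound is needed for the effect, a lower number that less compound is needed), a limit of > 11100 nM.
Compound 2 `Cc1ccc(S(=O)(=O)N[C@@H](CC(=O)NC(C)(C)C)C(=O)NCCNC(=O)c2cc(C)ccn2)cc1` gives in this assay a limit of > 11100 nM.
Compound 3 `Cc1ccc(S(=O)(=O)N[C@@H](CC(=O)NC(C)(C)C)C(=O)NCCNC(=O)c2cccc(F)c2)cc1` gives in this assay a limit of > 11100 nM.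

Compound 1 thus stands only at a limit in this assay, as do all values shown (the limit of > 11100 nM in this assay, at which 3 of the 3 values shown sit). Compound 4 `COc1cccc(C(=O)NCCNC(=O)[C@H](CC(=O)NC(C)(C)C)NS(=O)(=O)c2ccc(C)cc2)c1` differs from compound 1 in one place: methoxy in place of hydrogen on an aromatic carbon. The closest measured step is a step that the two limits leave unreadable from compound 1 to compound 3, likewise a substituent in place of hydrogen on the same ring; a step that the two limits leave unreadable from compound 1 to compound 2 and a step that the two limits leave unreadable from compound 2 to compound 3 are equally unreadable, so no step size in either direction can be drawn from the data. Compound 4 is expected to stay at the limit, a step that the limit leaves unreadable from compound 1 to compound 4, an expectation that no readable step supports. For compound 4 the estimate in this assay is 15000 nM, within 5000 nM to 50000 nM.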

Compound 4, half-maximal effective concentration: > 11100 nM
Compound 4 ended at the assay's limit; the forecaster's own chance of this, stated with the estimate: 85%; the middle value is on the limit's open side.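

No step can be read from compounds 1, 2, 3 and 4, all of which sit at a limit in this assay: the limit of > 11100 nM in this assay, at which 4 of the 4 values shown sit.

What the compounds shown leave open is how far any of these aryl changes moves cytotoxicity, since none yields a value short of the limit.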